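From Bromo to Ethyl on the Aromatic Ring

A few compounds are considered here, and "the series" means these few. Any claim that something is new, unique, unknown or untested is made for them only; others in the source may bear on it.

Of the compounds shown here, two have been measured so far. Compound 1 `C=CCc1cccc(CC=C)c1OC(C)C1=NCCN1` gives 0.65 in an assay on CHO cells with Alpha-2B adrenergic receptor (Homo sapiens) as the target; on this read-out lower numbers stand for smaller maximal responses and higher numbers for larger maximal responses. Compound 2 `CC(Oc1ccccc1Br)C1=NCCN1` gives 0.4 in this assay; this is the lower of the two numbers, and the gap to compound 1 lies beyond the usual scatter of repeated measurements.

Compound 3 `CCc1ccccc1OC(C)C1=NCCN1` has not yet been measured. It differs from compound 2 in one place only: ethyl in place of bromo on an aromatic carbon. The change sits on an aromatic carbon of a six-membered aromatic ring of carbon only, ortho to a group of 8 heavy atoms.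

For the measured compounds named here, no two measured compounds differ in just one place, so no step of this kind has been observed, and the two values of compound 1 and compound 2 alone do not show what such an exchange does. On that basis the step from compound 2 to compound 3 is expected to be small, a number 0.080 higher from compound 2 to compound 3 (within the scatter), most likely no larger than the scatter, with a slight lean upward. For compound 3 the estimated maximal response is 0.48, with a likely range from 0.3 to 0.68.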

Compound 3, intrinsic activity: the largest response reached, as a fraction of the reference agonist's: 0.5
The estimate for compound 3 lay 0.020 below the measured number, within the range that was stated.
By their numbers in this assay, from the lowest: compounds 2 and 3 (each within the scatter of the next); then compound 1.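

In this assay, for the compounds shown here, the exchange of bromo for ethyl on an aromatic carbon gives a number 0.10 higher from compound 2 to compound 3 (within the scatter) and is the first step here in which only one place changes. At this position, ortho to a group of 8 heavy atoms, a single bromine atom and an ethyl group with its 2 carbons therefore cannot be told apart on this read-out, even though the entering group has one more heavy atom than the group that leaves. No accompanying measurement bears on the reason for this result.

As far as these compounds go, it remains open whether the same place would accept very different groups, such as an amine, a carboxylic acid or a longer chain like butyl, while keeping the maximal response within the scatter of compound 2 and compound 3. Compound 1 differs from compound 3 in more than one place, so the compounds shown do not assign its value to any single change on the aromatic ring.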